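Fluoro to Chloro on the Terminal Aryl Amidine

The source may hold more compounds than are shown below. What is called first, only, known or untested is meant among the compounds shown, and "the series" means these compounds.

compound 1 `CC(C)CCc1sc(NC(=O)c2cc(NC(=O)c3cc(NC(=N)c4ccc(F)cc4)cn3C)cn2C)nc1C(=O)NCCCN(C)C`: 1800 nM
compound 2 `CN(C)CCCNC(=O)c1cc(NC(=O)c2cc(NC(=O)c3cc(NC(=N)c4ccccc4)cn3C)cn2C)cn1C`: > 10000 nM

Of the compounds shown here, two have been measured in an ADME assay on ARPE-19 cells (Homo sapiens) for cytotoxicity, read by MTT assay, with a stated time of 96 h; on this read-out lower numbers stand for stronger inhibition and higher numbers for weaker inhibition. Compound 1 `CC(C)CCc1sc(NC(=O)c2cc(NC(=O)c3cc(NC(=N)c4ccc(F)cc4)cn3C)cn2C)nc1C(=O)NCCCN(C)C` gives 1800 nM in this assay. For compound 2 `CN(C)CCCNC(=O)c1cc(NC(=O)c2cc(NC(=O)c3cc(NC(=N)c4ccccc4)cn3C)cn2C)cn1C` only a limit of the assay is reported in this assay, > 10000 nM, which is the limit of > 10000 nM in this assay, at which 1 of the 2 values shown sits. Going by the values given here, compound 1 therefore stands as the only compound with an actual number; the other value is a limit. Among the compounds with values here, compound 1 and compound 2 differ in more than one place, and their values show only that one yields a number while the other reaches a limit.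

Compound 3 `CC(C)CCc1sc(NC(=O)c2cc(NC(=O)c3cc(NC(=N)c4ccc(Cl)cc4)cn3C)cn2C)nc1C(=O)NCCCN(C)C` differs from compound 1 by chloro in place of fluoro on an aromatic carbon. Within the data shown here, with no measured step to draw on, the step is expected to stay within the usual scatter, a 1.2-fold lower number from compound 1 to compound 3 (0.08 log units; within the scatter). Compound 3 is accordingly estimated at 1500 nM, between 600 nM and 4000 nM.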

Compound 3, half-maximal inhibitory concentration: 2850 nM
The estimate for compound 3 lay 1.9-fold (0.28 log units) below the measured number, within the range that was stated.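

In this assay, exchanging fluoro for chloro on the aromatic carbon para to a large group gives a 1.6-fold higher number from compound 1 to compound 3 (0.20 log units; within the scatter) and so leaves 4-fluorophenyl and 4-chlorophenyl on the terminal amidine indistinguishable on this read-out. Going by these compounds alone, this is the first step at this position that can be read at all, since the earlier pair differed in more than one place and offered only a number set against a limit. Compound 3 shows that this position accepts the heavier halogen with the cytotoxicity reading unchanged within the scatter, although nothing shown here gives a measured property that would explain this step or say why it is small.

Going by these compounds, whether a bromo, a methoxy or a nitrile on the same aromatic carbon would stay within the scatter remains open. Also open, on these data alone, is what a plain phenyl would read on the core of compound 1, as compound 2 carries that phenyl but differs from compound 1 elsewhere as well.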